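The source may hold more compounds than are shown below. What is called first, only, known or untested is meant among the compounds shown, and "the series" means these compounds.

Working notes on the series. Of the compounds shown here, two of the shared core have been measured. Compound 1 `COc1cc(OC)cc(-n2c(-c3ccccc3)nc(C)c2C)c1` gives 55.6% in a functional assay, read by spectrophotometry, with a stated time of 30 min, tested at 50 uM; on this read-out lower numbers stand for a weaker effect and higher numbers for a stronger effect at the one concentration tested. Compound 2 `COc1ccc(-n2c(-c3ccc(F)cc3)nc(C)c2C)cc1` gives 68.7% in this assay. Of these two numbers compound 2 stands highest. Its gap from compound 1 lies beyond the usual scatter of repeated measurements of this kind.

Compound 3 `COc1ccc(-n2c(-c3ccccc3)nc(C)c2C)cc1` is the next member to be measured. Relative to compound 2 the change is hydrogen in place of fluoro on an aromatic carbon. For the measured compounds named here, no step between measured compounds that differ in one place is available, so the size of this change can only be estimated. Compound 1, which also carries no fluoro, gives 55.6% in this assay, but compound 1 and compound 2 differ in more than one place, so their values give no direct guide to the fluoro alone. The step of a number 10.7 percentage points lower from compound 2 to compound 3 (beyond the scatter) is expected to be a modest decrease, close to the edge of the scatter. For compound 3 the expected value in this assay is 58%, with a range from 42% to 72%.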

Compound 3, a percentage reported as activity, at one concentration (the size of the read-out at that concentration, not a potency): 55.6%
Compound 3: middle estimate off by 2.4 percentage points, on the high side, and the stated range covers the measured number.
By their numbers in this assay, from the lowest: compounds 1 and 3 (each within the scatter of the next); then compound 2.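

For the compounds shown here, the change from 4-fluorophenyl to phenyl now has a measured size: in this assay it appears as a number 13.1 percentage points lower from compound 2 to compound 3 (beyond the scatter) and this is the first step that isolates one place. It shows that the read-out at the one concentration tested responds to what sits on this aromatic carbon, para to a large group, with fluoro giving the stronger effect of the two groups compared here, though this is a single pair and says nothing about potency. No measurement among these compounds accounts for the size or direction of this step.

Still open, going by these compounds, is how a chloro, a methoxy, an amine or a carboxylic acid on this aromatic carbon would compare with fluoro and hydrogen in this assay and whether the order would extend beyond this pair. Also open, on these data alone, is whether the fluoro step would keep its size on the core of compound 1, since one step on one pair of compounds cannot show how far it carries across the series.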